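Chloro in place of hydrogen on the compound 2 scaffold

The source may report more compounds than this note shows. Statements on the series, on what has been measured and on what is new or still open speak of the compounds shown alone.

Measured so far:
compound 1 `C/C(=N\O)c1ccc(NC(=O)Cn2nc(-c3ccc(Cl)cc3)nc2N)cc1` gives 34%
compound 2 `c1ccc(-c2nc3sc(-c4ccccc4)cn3n2)cc1` gives 53%
compound 3 `C/C(=N/O)c1ccc(NC(=O)Cn2nc(C(F)(F)F)nc2N)cc1` gives 15.1%

In a functional assay on UO-31 cells (Homo sapiens) for inhibition, read by sulforhodamine B assay, with a stated time of 48 h, tested at 10 uM (on this read-out lower numbers stand for less inhibition of growth and higher numbers for more inhibition of growth at the one concentration tested), compound 2 stands highest of the three measured compounds. Its nearest neighbour on the numbers is compound 1, which lies lower by a margin beyond the scatter; compound 3 lies lower still, also beyond the scatter. Among the compounds with values here, no two measured compounds differ in only one place, so no single-step comparison is available, and compound 2 is the only compound built on its core.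

Compound 4 `Clc1ccc(-c2cn3nc(-c4ccccc4)nc3s2)cc1` is the untested analogue of compound 2. The change is chloro in place of hydrogen on an aromatic carbon. Within the data shown here, no measured pair in this set tests the same change, so there is no direct guide to its effect.

Given the absence of any comparable step, the expected movement from compound 2 to compound 4 is small: a number 3 percentage points higher from compound 2 to compound 4 (within the scatter) is estimated to lie within the usual scatter, with a slight lean upward. Compound 4 is therefore expected to give about 56% in this assay, in the range 36% to 74%.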

Compound 4, percent growth inhibition at one concentration: 40%
Estimate against measurement, compound 4: 16 percentage points above; measured number inside the range.
By their numbers in this assay, from the lowest: compound 3; then compounds 1 and 4 (each within the scatter of the next); then compound 2.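

In this assay, within the data shown here, phenyl to 4-chlorophenyl gives a number 13 percentage points lower from compound 2 to compound 4 (beyond the scatter), the only single-step comparison available. It shows that this aromatic carbon, para to a large group, is not indifferent to substitution: on this core, chloro in place of hydrogen lowers growth inhibition at the one concentration tested rather than raising it. Nothing available on the compounds bears on the reason for this movement.

The compounds shown leave open whether the loss is particular to chloro or would also follow a methoxy group, an amine or a carboxylic acid on the same carbon. They also leave open whether chloro in place of hydrogen on the other phenyl ring of the core would move the number in the same direction.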